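This account rests on a few compounds, and the source may have more. Where it says the series, first, only, none or still open, it means among the compounds named here.

Measured in a functional assay on MDA-MB-231 cells (Homo sapiens) for inhibition, read by MTT assay, with a stated time of 72 h; a higher number here means a weaker inhibitor, a lower number a stronger inhibitor:
- Compound 1 `Nc1nc2cc(-c3nn(CCC(=O)NO)c4ncnc(N)c34)ccc2o1`: > 50000 nM
- Compound 2 `Nc1ncnc2c1c(-c1cnc3[nH]ccc3c1)nn2CCCC(=O)NO`: > 150000 nM

Compound 1 stands only at a limit, > 50000 nM, not at a number. Compound 2 likewise reports only a limit, > 150000 nM.

Compound 3 `CNC(=O)CCCCCCCn1nc(-c2ccc3oc(N)nc3c2)c2c(N)ncnc21` has not yet been measured. It carries 5-(methylcarbamoyl)pentyl in place of hydroxycarbamoyl on a saturated chain carbon, two bonds along the chain from an aromatic nitrogen.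

Within the data shown here, no measured step guides the change, so no shift beyond the scatter is expected in this assay. The estimated step is a step that the limit leaves unreadable from compound 1 to compound 3. Compound 3 is expected at 60000 nM, within an estimated range of 15000 nM to 200000 nM.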

Compound 3, half-maximal inhibitory concentration: 2900 nM
Beside the measured number, compound 3's estimate is 21-fold (1.32 log units) above it; the whole stated range lies above it.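

In this assay, among these compounds, 5-(methylcarbamoyl)pentyl in place of hydroxycarbamoyl gives an at least 17-fold lower number from compound 1 to compound 3 (1.23 log units; beyond the scatter) and brings the first value in this set that is a number rather than a limit. Hydroxycarbamoyl is therefore not needed at this position for a measurable value in this assay. The size of the step remains a bound, because compound 1 gives only a limit: the limit of > 50000 nM in this assay, at which 1 of the 3 values shown sits. The change alters chain length and end group together, so the compounds shown do not separate the two. A longer chain ending in hydroxycarbamoyl or a carboxylic acid would test each.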